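The source may report more compounds than this note shows. Statements on the series, on what has been measured and on what is new or still open speak of the compounds shown alone.

Series notes. Compound 1 `CC(C)c1c(C(=O)NCc2cccc(F)c2F)nn(-c2ccc(F)cc2)c1OC[C@@H](O)C[C@@H](O)CC(=O)O`, compound 2 `Cc1ccc(CNC(=O)c2nn(-c3ccc(F)cc3)c(OC[C@@H](O)C[C@@H](O)CC(=O)O)c2C(C)C)cc1` and compound 3 `CC(C)c1c(C(=O)N2CCCCC2)nn(-c2ccc(F)cc2)c1OC[C@@H](O)C[C@@H](O)CC(=O)O` share one core and differ only in the group on the carbonyl carbon. In an assay on microsomes from liver for inhibition of 3-hydroxy-3-methylglutaryl-coenzyme A reductase (Rattus norvegicus) (a higher number here means a weaker inhibitor, a lower number a stronger inhibitor), compound 1 gives 2 nM, compound 2 gives 15 nM and compound 3 gives 47 nM. Compound 3 therefore holds the highest number of the three measured compounds: a 3.1-fold higher number from compound 2 to compound 3 (0.50 log units; beyond the scatter), and a 24-fold higher number from compound 1 to compound 3 (1.37 log units; beyond the scatter). The change to compound 4 `COc1ccc(CNC(=O)c2nn(-c3ccc(F)cc3)c(OC[C@@H](O)C[C@@H](O)CC(=O)O)c2C(C)C)cc1` is (4-methoxybenzyl)amino in place of piperidin-1-yl on a carbonyl carbon. Both measured steps bear on it, as each put piperidin-1-yl in place of a benzylamino group and each carried the number upward; the closer comparison is a 3.1-fold higher number from compound 2 to compound 3 (0.50 log units; beyond the scatter), compound 2 bearing a 4-methylbenzyl group where compound 4 bears a 4-methoxybenzyl group. Reversing that step points to a lower number for compound 4 in this assay. Within the data shown here, no measured pair shows how a methoxy substituent compares with a methyl substituent on that ring, so the expected size is taken from compound 2 alone: the expected step is a 2.6-fold lower number from compound 3 to compound 4 (0.42 log units; beyond the scatter). Compound 4 is estimated at 18 nM, within a range from 6 nM to 50 nM.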

Compound 4, half-maximal inhibitory concentration: 12 nM
Compound 4: middle estimate off by 1.5-fold (0.18 log units), on the high side; low and high end bracket the measured number.
By their numbers in this assay, from the lowest: compound 1; then compounds 4 and 2 (each within the scatter of the next); then compound 3.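

In this assay, among these compounds, methoxy in place of methyl on an aromatic carbon gives a 1.3-fold lower number from compound 2 to compound 4 (0.10 log units; within the scatter), the first direct comparison of these two substituents, and it does not separate them. Swapping the piperidin-1-yl group for (4-methoxybenzyl)amino gives a 3.9-fold lower number from compound 3 to compound 4 (0.59 log units; beyond the scatter), so all three benzylamino groups shown now carry lower numbers than piperidin-1-yl, with no compound against that pattern. The 2,3-difluorophenyl group keeps its lead over this new ring as well, with 4-methoxyphenyl in its place giving a 6.0-fold higher number from compound 1 to compound 4 (0.78 log units; beyond the scatter).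

No measurement at hand accounts for any of these steps. Still open, on these data alone, is how a phenethylamino or morpholin-4-yl group on the carbonyl carbon would compare, and whether a single fluorine on the benzyl ring would match the 2,3-difluorophenyl group.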